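A few compounds are considered here, and "the series" means these few. Any claim that something is new, unique, unknown or untested is made for them only; others in the source may bear on it.

Of the compounds shown here, three sharing one core have been measured in an assay on CHO cells for displacement of a labelled ligand from 5-hydroxytryptamine receptor 1B (Homo sapiens); a higher number here means a weaker inhibitor, a lower number a stronger inhibitor. Compound 1 `c1cc(CN2CCN(CCCc3c[nH]c4ccc(-n5cnnc5)cc34)CC2)ccn1` gives 23 nM. Compound 2 `CC(=O)Nc1ccc(CN2CCN(CCCc3c[nH]c4ccc(-n5cnnc5)cc34)CC2)cc1` gives 56 nM. Compound 3 `c1cc2[nH]cc(CCCN3CCNCC3)c2cc1-n1cnnc1` gives 145 nM, the highest of the three numbers, so it is the weakest inhibitor among them. The steps leading to it show what a group on the ring nitrogen of the shared core is worth: removing (pyridin-4-yl)methyl gave a 6.3-fold higher number from compound 1 to compound 3 (0.80 log units; beyond the scatter), and removing 4-acetamidobenzyl gave a 2.6-fold higher number from compound 2 to compound 3 (0.41 log units; beyond the scatter), while swapping one of these groups for the other gave a 2.4-fold higher number from compound 1 to compound 2 (0.39 log units; beyond the scatter).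

Compound 4 `CN1CCN(CCCc2c[nH]c3ccc(-n4cnnc4)cc23)CC1` goes the other way from compound 3 by the smallest possible addition: methyl in place of hydrogen on an amine nitrogen in a ring. Both measured removals from that nitrogen weakened binding by a modest amount, so a group there seems to help, but a single carbon is far smaller than either benzyl group. Compound 4 is therefore expected to show only a small improvement, a 1.5-fold lower number from compound 3 to compound 4 (0.16 log units; within the scatter), with a value around 100 nM, estimated to lie between 40 nM and 250 nM in this assay.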

Compound 4, half-maximal inhibitory concentration: 309 nM
Compound 4: the middle estimate sits 3.1-fold (0.49 log units) below what was measured, and the stated range ends below it.
By their numbers in this assay, from the lowest: compound 1; then compound 2; then compound 3; then compound 4.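

In this assay, adding one methyl to the ring nitrogen does not give a small share of the gain seen with the larger groups; it goes the opposite way (a 2.1-fold higher number from compound 3 to compound 4 (0.33 log units; beyond the scatter)). A group on this nitrogen therefore does not help simply by being there, and the outcome depends on which group it is, as the gaps to the two larger groups show (a 5.5-fold higher number from compound 2 to compound 4 (0.74 log units; beyond the scatter); a 13-fold higher number from compound 1 to compound 4 (1.13 log units; beyond the scatter)). Nothing available here explains why a single carbon and the larger groups pull in opposite directions.

Still open, going by these compounds, is where along the way from methyl to the larger groups binding starts to improve. An ethyl group, a plain benzyl or a 2-phenylethyl chain on the same nitrogen would help to locate that point.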